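Adding a hydroxy to the phenyl ring of compound 3

The source may report more compounds than this note shows. Statements on the series, on what has been measured and on what is new or still open speak of the compounds shown alone.

Of the compounds shown here, three sharing one core have been measured in an ADME assay, in phosphate buffer, at 28 degrees C, at pH 7.0; a lower number here means that the compound disappears faster, a higher number that the compound lasts longer. Compound 1 `C[C@@H](O)[C@H]1C(=O)N2C(C(=O)O)=C(C(C)(C)C)O[C@H]12` gives 8.1 h. Compound 2 `COC(=O)[C@@H](O)[C@H]1C(=O)N2C(C(=O)O)=C(C(C)(C)C)O[C@H]12` gives 6.2 h. Compound 3 `CC(C)(C)C1=C(C(=O)O)N2C(=O)[C@H]([C@H](O)CCc3ccccc3)[C@H]2O1` gives 21 h, the highest of the three numbers; the steps of a 2.6-fold higher number from compound 1 to compound 3 (0.41 log units; beyond the scatter) and a 3.4-fold higher number from compound 2 to compound 3 (0.53 log units; beyond the scatter) both lie beyond the scatter, while the step of a 1.3-fold lower number from compound 1 to compound 2 (0.12 log units; within the scatter) lies within it.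

Compound 4 `CC(C)(C)C1=C(C(=O)O)N2C(=O)[C@H]([C@H](O)CCc3ccc(O)cc3)[C@H]2O1` differs from compound 3 in one place: hydroxy in place of hydrogen on an aromatic carbon. None of the three measured steps touches the aromatic ring itself; they all alter the group on the saturated chain carbon that carries the hydroxy, and only the two steps that bring in the phenyl-bearing chain move the number beyond the scatter. Nothing measured here tells how a change on that ring shifts this assay. The step from compound 3 to compound 4 is therefore expected to be small, a 1.2-fold lower number from compound 3 to compound 4 (0.07 log units; within the scatter), with no clear direction beyond the scatter. Compound 4 is estimated at 18 h, between 9 h and 36 h.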

Compound 4, half-life: 24.6 h
The estimate for compound 4 lay 1.4-fold (0.14 log units) below the measured number; the range from low to high includes it.
By their numbers in this assay, from the lowest: compounds 2 and 1 (each within the scatter of the next); then compounds 3 and 4 (each within the scatter of the next).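

In this assay, the only change among these compounds that falls on the aromatic ring itself, hydroxy in place of hydrogen para to a large group, gives a 1.2-fold higher number from compound 3 to compound 4 (0.07 log units; within the scatter) and so leaves no readable shift at this position. The gain seen with the benzyl extension also survives the added hydroxy: a 2.6-fold higher number from compound 1 to compound 3 (0.41 log units; beyond the scatter) and a 3.0-fold higher number from compound 1 to compound 4 (0.48 log units; beyond the scatter) both lie beyond the scatter, so the chain ending in 4-hydroxybenzyl keeps compound 4 clear of compound 1 just as the unsubstituted chain does for compound 3. No information is available on why the ring tolerates this change in this assay. Going by these compounds, these compounds test one group at one ring position, so it remains open whether a larger or differently built group there, such as an amine, a carboxylic acid or a methoxy, would also leave the half-life within the scatter. On these data alone, it is equally open whether a hydroxy placed elsewhere on the ring would behave as it does in compound 4, or whether the ring could be replaced altogether without losing the gain over compound 1.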